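Aryloxy benzenesulfonylureas: isopropyl to tert-butyl on the urea

This account rests on a few compounds, and the source may have more. Where it says the series, first, only, none or still open, it means among the compounds named here.

Three compounds have numbers in a functional assay on HEK293 cells for antagonist activity at thromboxane A2 receptor (Homo sapiens), read by fluorescence and calcium flux; a higher number here means a weaker inhibitor, a lower number a stronger inhibitor. Compound 1 `Cc1ccccc1Oc1ccc(C#N)cc1S(=O)(=O)NC(=O)NC(C)(C)C` gives 1470 nM; compound 2 `Cc1ccc(Oc2ccc(C#N)cc2S(=O)(=O)NC(=O)NC(C)(C)C)cc1` gives 680 nM; compound 3 `CC(C)NC(=O)NS(=O)(=O)c1cc(C#N)ccc1Oc1ccc(Br)cc1` gives 9130 nM, the highest of the three. For the measured compounds named here, the one single-point step measured so far, a 2.2-fold lower number from compound 1 to compound 2 (0.33 log units; beyond the scatter), concerns the aryloxy part, not the urea end. Compound 4 `CC(C)(C)NC(=O)NS(=O)(=O)c1cc(C#N)ccc1Oc1ccc(Br)cc1` differs from compound 3 by methyl in place of hydrogen on a saturated chain carbon bound to an amide-type nitrogen and two saturated chain carbons, that is, isopropyl to tert-butyl on the urea nitrogen. Going by the values given here, no measured pair isolates that change; compounds 1 and 2 carry tert-butyl yet also differ from compound 3 in the aryloxy ring, so they only hint that tert-butyl sits with lower numbers. A modest decrease, a 2.6-fold lower number from compound 3 to compound 4 (0.42 log units; beyond the scatter), is therefore expected, with wide uncertainty. Compound 4 is estimated at 3500 nM, within 1200 nM to 10000 nM.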

Compound 4, half-maximal inhibitory concentration: 5310 nM
Estimate against measurement, compound 4: 1.5-fold (0.18 log units) below, within the range that was stated.
By their numbers in this assay, from the lowest: compound 2; then compound 1; then compounds 4 and 3 (each within the scatter of the next).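

For the compounds shown here, with the aryloxy part held as 4-bromophenyl, isopropyl to tert-butyl on the urea nitrogen gives a 1.7-fold lower number from compound 3 to compound 4 (0.24 log units; within the scatter), the first isolated reading of this change, and the added methyl leaves the two values within the scatter of each other. The steps beyond the scatter lie on the aryloxy side: a 7.8-fold higher number from compound 2 to compound 4 (0.89 log units; beyond the scatter) for bromo in place of methyl on an aromatic carbon, and a 3.6-fold higher number from compound 1 to compound 4 (0.56 log units; beyond the scatter) for 4-bromophenyl in place of 2-methylphenyl. No supporting evidence accounts for these steps.

Going by these compounds, it remains open whether cyclohexyl or a longer chain on the urea nitrogen would shift the number beyond the scatter. Also open, on these data alone, is whether isopropyl to tert-butyl reads the same with another aryloxy group, such as 4-chlorophenyl.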